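The compounds below may be only part of what the source reports. "The series", "measured", "known", "first", "only" and "open" are said of these compounds alone.

Measured compounds:
compound 1, `Cc1ccccc1NC(=O)N1CCC(c2nc(-c3ccc4ccccc4n3)no2)CC1`: 440 nM
compound 2, `Cn1c(-c2noc(C3CCN(C(=O)NC4CCS(=O)(=O)CC4)CC3)n2)nc2ccccc21`: 350 nM

In a functional assay on Shh Light II cells (Mus musculus) for inhibition, read by a luciferase reporter (on this read-out higher numbers stand for weaker inhibition and lower numbers for stronger inhibition), compound 1 gives 440 nM. Compound 2 gives 350 nM in this assay, and the gap between the two numbers lies within the usual scatter of repeated measurements, so the two compounds cannot be told apart on this read-out. For the measured compounds named here, no pair of measured compounds differing in a single place is available, so nothing measured shows how a change at the urea-type nitrogen moves the number.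

Compound 3, `O=C(Nc1cccnc1Cl)N1CCC(c2nc(-c3ccc4ccccc4n3)no2)CC1`, differs from compound 1 only here: 2-chloropyridin-3-yl in place of 2-methylphenyl on an amide-type nitrogen. Going by the values given here, with no measured step to lean on, the expected step is a 1.0-fold higher number from compound 1 to compound 3 (0.01 log units; within the scatter), meaning no change beyond the scatter is expected in either direction. Compound 3 is therefore estimated at 450 nM in this assay, with a range from 180 nM to 1100 nM.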

Compound 3, half-maximal inhibitory concentration: 1600 nM
Compound 3: the middle estimate sits 3.6-fold (0.55 log units) below what was measured; measured number above the stated range.
By their numbers in this assay, from the lowest: compounds 2 and 1 (each within the scatter of the next); then compound 3.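

In this assay the group on the amide-type nitrogen proves able to move the number: 2-chloropyridin-3-yl in place of 2-methylphenyl gives a 3.6-fold higher number from compound 1 to compound 3 (0.56 log units; beyond the scatter) with the rest of the molecule unchanged. For the compounds shown here, this is the first single-place step, and it runs towards weaker inhibition, which the two earlier compounds, lying within the scatter of each other and differing in more than one place, could not show. Nothing measured here accounts for the loss, so it stands as an observation without an explanation.

The ring nitrogen and the chlorine enter together, so the compounds shown do not tell which of them goes with the weaker inhibition. On these data alone, how a plain phenyl, or a phenyl carrying an amine or a carboxylic acid, would read on this same nitrogen remains open.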